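This account rests on a few compounds, and the source may have more. Where it says the series, first, only, none or still open, it means among the compounds named here.

For the measured compounds named here, compound 1 `Cc1ccccc1COc1nc2c(cc1-c1nc(N)cc(N)n1)c(C)nn2-c1ccccc1` gives 290 nM in a functional assay on aorta (Rattus norvegicus, strain Sprague-Dawley) (a lower number here means that less compound is needed, a higher number that more compound is needed for the effect), and is so far the only compound here with a number. Compound 2 `Cc1nn(-c2ccccc2)c2nc(OCc3ccc(F)cc3)c(-c3nc(N)cc(N)n3)cc12` carries a 4-fluorobenzyl group, and for compound 2 the entry reads "not determined" (no result reported) so it has no place on the scale and offers no starting value. Compound 3 `Cc1nn(-c2ccccc2)c2nc(OCc3ccc(C(F)(F)F)cc3)c(-c3nc(N)cc(N)n3)cc12` is the next structure to be tested. One place changes, trifluoromethyl in place of fluoro on an aromatic carbon and the change is trifluoromethyl in place of fluoro on an aromatic carbon, turning 4-fluorobenzyl into 4-(trifluoromethyl)benzyl. Going by the values given here, without a number for compound 2, no size can be read for this change in this assay, and the only guide is compound 1 at 290 nM as the sole measured value. For compound 3 the estimated value is 300 nM with 80 nM to 1100 nM as the expected range.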

Compound 3, half-maximal effective concentration: 1600 nM
Compound 3: the middle estimate sits 5.3-fold (0.73 log units) below what was measured; measured number above the stated range.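

For the compounds shown here, the one step that can be read is a 5.5-fold higher number from compound 1 to compound 3 (0.74 log units; beyond the scatter) in this assay, with 4-(trifluoromethyl)phenyl in place of 2-methylphenyl, which shows that the group carried on this oxygen matters: changing it moves the number beyond the usual scatter, and more compound is needed for the effect. As far as these compounds go, the step from fluoro to trifluoromethyl cannot be read, as compound 2 has no number, so the effect of that change alone remains unknown. Nothing shown here explains the higher number.

Compound 1 and compound 3 differ in both the group on the aromatic ring and where it sits, and these two compounds cannot separate the two. Also open, from the compounds shown here alone, is how a plain unsubstituted benzyl, a 4-methylbenzyl or a 4-methoxybenzyl group would compare at this position.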